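Oxime against ketone on the thioether chain, two cores

A few compounds are considered here, and "the series" means these few. Any claim that something is new, unique, unknown or untested is made for them only; others in the source may bear on it.

Compound 1 `C=CCn1c(SC/C(=N/O)c2ccccc2)nnc1-c1ccc(OC)cc1` and compound 2 `C=CCn1c(SCC(=O)c2ccccc2)nnc1-c1ccc(OC)cc1` share one core and differ in a single place, where (a group of 8 heavy atoms (7 carbon, 1 oxygen; one six-membered aromatic ring of carbon only) in place of a group of 9 heavy atoms (7 carbon, 1 nitrogen, 1 oxygen; one six-membered aromatic ring of carbon only), on a saturated chain carbon bound to a sulfur). In a functional assay on the whole organism (strain albino) for inhibition, with Rattus norvegicus as the target, read by paw edema, with a stated time of 1 h, at a dose of 0.28 mmol/kg by the oral route (on this read-out higher numbers stand for more inhibition at the one dose given (going by the name of the read-out) and lower numbers for less inhibition), compound 1 gives 61%, and compound 2 gives 49%; the step is a number 12 percentage points lower from compound 1 to compound 2 (beyond the scatter). Compound 3 `CCn1c(SC/C(=N/O)c2ccccc2)nnc1-c1ccc(OC)c(OC)c1` is built on a second core; how that core differs from the core of compound 1 is not broken down here. In this assay compound 3 gives 61%, level with compound 1 at the digits shown and within the scatter of it. Compound 4 `CCn1c(SCC(=O)c2ccccc2)nnc1-c1ccc(OC)c(OC)c1` has not been measured; it stands to compound 3 as compound 2 stands to compound 1, with a group of 8 heavy atoms (7 carbon, 1 oxygen; one six-membered aromatic ring of carbon only) in place of a group of 9 heavy atoms (7 carbon, 1 nitrogen, 1 oxygen; one six-membered aromatic ring of carbon only), on a saturated chain carbon bound to a sulfur. The place is described in the same words for both pairs, so this is the same change made a second time, on the other core. Going by the values given here, the single measured example of it is the modest downward step a number 12 percentage points lower from compound 1 to compound 2 (beyond the scatter), and a step of similar size is expected here, namely a number 12 percentage points lower from compound 3 to compound 4 (beyond the scatter). The estimate for compound 4 in this assay is 49%, with an expected span from 38% to 60%.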

Compound 4, a percentage reported as inhibition, in the whole organism at one dose (the size of the read-out at that dose, not a potency): 42%
Estimate against measurement, compound 4: 7 percentage points above; the range from low to high includes it.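

In this assay, benzoyl in place of the oxime-bearing group, on a saturated chain carbon bound to a sulfur, again lowers the number on the second core, with a number 19 percentage points lower from compound 3 to compound 4 (beyond the scatter). The two steps agree in direction and do not differ in size: the same change on two cores in this assay, a number 12 percentage points lower (beyond the scatter) from compound 1 to compound 2 and a number 19 percentage points lower (beyond the scatter) from compound 3 to compound 4, 7 percentage points apart, within the scatter of two such steps. On these two pairs the change therefore carries from one core to the other, but two cores cannot show that it would hold on a third, and a single read-out at one dose and one time says nothing about why the oxime compounds read higher.

Still open, on these data alone, is how the two cores compare when each part of them is changed alone, since compound 1 and compound 3 differ by more than one feature of the core. Also open, as far as these compounds go, is what other groups would do at this place on the chain, such as an oxime methyl ether, an amine, a carboxylic acid or a longer chain between the sulfur and the phenyl ring.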